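This account rests on a few compounds, and the source may have more. Where it says the series, first, only, none or still open, it means among the compounds named here.

Measured so far in a functional assay on U-87MG ATCC cells for cytotoxicity against U-87 MG (Homo sapiens), read by MTT assay, with a stated time of 48 h; a lower number here means a stronger inhibitor, a higher number a weaker inhibitor:
compound 1 `CCCCCCCCCC[n+]1cccc(O)c1` gives 158000 nM
compound 2 `O=C(O[C@H]1C[C@H](n2cc(F)c(=O)[nH]c2=O)O[C@@H]1COP(=O)(O)Oc1ccccc1)c1ccccc1` gives 800 nM
compound 3 `O=C(O[C@H]1C[C@H](n2cc(F)c(=O)[nH]c2=O)O[C@@H]1COP(=O)(O)Oc1cccnc1)c1ccccc1` gives 710 nM

Compound 3 stands at the lowest of the three numbers, but its one-place step from compound 2, a 1.1-fold lower number from compound 2 to compound 3 (0.05 log units; within the scatter), is within the scatter, so compounds 2 and 3 cannot be told apart on these data. For the measured compounds named here, compound 1, with no single-point step to either, sits far beyond the scatter at the high end.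

The next compound, compound 4 `O=C(O[C@H]1C[C@H](n2cc(F)c(=O)[nH]c2=O)O[C@@H]1COP(=O)(O)Oc1ccc2ncccc2c1)c1ccccc1`, is still to be measured in this assay. It differs from compound 3 in one place: quinolin-6-yl in place of pyridin-3-yl on an oxygen. Going by the values given here, the only measured step that bears on this change is the one on the same oxygen, a 1.1-fold lower number from compound 2 to compound 3 (0.05 log units; within the scatter), where phenyl became pyridin-3-yl without movement beyond the scatter. Among the compounds with values here, no measured pair shows quinolin-6-yl, so the effect of the added six-membered aromatic ring of carbon only is not known from these numbers. Within the data shown here, with the single comparable step being flat, the expected step for compound 4 is a 1.1-fold lower number from compound 3 to compound 4 (0.04 log units; within the scatter), which is not beyond the scatter. Compound 4 is therefore estimated at 650 nM, with a range from 250 nM to 1800 nM.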

Compound 4, half-maximal inhibitory concentration: 880 nM
For compound 4 the middle estimate is 1.4-fold (0.13 log units) below the measured one; the range from low to high includes it.
By their numbers in this assay, from the lowest: compounds 3, 2 and 4 (each within the scatter of the next); then compound 1.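

On the oxygen whose other neighbour is phosphorus, in this assay, replacing pyridin-3-yl with quinolin-6-yl adds a six-membered aromatic ring of carbon only and gives a 1.2-fold higher number from compound 3 to compound 4 (0.09 log units; within the scatter) with no readable change; the earlier compounds had shown only the exchange of one single aromatic ring for another, so this is the first sign that a larger aromatic group is accepted at this position in this series. Measured directly against phenyl, the same position gives a 1.1-fold higher number from compound 2 to compound 4 (0.04 log units; within the scatter) and thus phenyl, pyridin-3-yl and quinolin-6-yl cannot be told apart here, so neither the ring nitrogen nor the added ring has a visible effect in these three compounds. No supporting data bear on this flat result.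

Open, on these data alone, is whether any group on this oxygen moves the number beyond the scatter, for example a longer chain in place of the aromatic ring, or an amine or a carboxylic acid carried on that ring. For the compounds shown here, compound 1 differs from the others in more than one place, so no step to it can be read, and the part of the shared core away from this oxygen remains untested by these comparisons.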